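A few compounds are considered here, and "the series" means these few. Any claim that something is new, unique, unknown or untested is made for them only; others in the source may bear on it.

Working notes on the series. Compound 1 `CCc1nnn(Cc2ccc(C(F)(F)F)cc2)c1C(=O)N[C@@H](C)c1ccc(C(=O)O)cc1` carries ethyl on the aromatic carbon of the shared core. In a functional assay on CHO cells for antagonist activity at prostaglandin E2 receptor EP4 subtype (Homo sapiens), read by calcium flux, with a stated time of 15 min (on this read-out higher numbers stand for weaker inhibition and lower numbers for stronger inhibition), compound 1 returns only > 10000 nM, which is a limit of the assay and not a number (the limit of > 10000 nM in this assay, at which 1 of the 3 values shown sits). Compound 2 `CCCc1nnn(Cc2ccc(C(F)(F)F)cc2)c1C(=O)N[C@@H](C)c1ccc(C(=O)O)cc1` gives 68.8 nM in this assay, and the step of an at least 140-fold lower number from compound 1 to compound 2 (2.16 log units; beyond the scatter) is large. Compound 3 `C[C@H](NC(=O)c1c(C2CCCCC2)nnn1Cc1ccc(C(F)(F)F)cc1)c1ccc(C(=O)O)cc1` gives 161 nM in this assay. Against compound 1 the step of an at least 62-fold lower number from compound 1 to compound 3 (1.79 log units; beyond the scatter) is also large, while against compound 2 the step of a 2.3-fold higher number from compound 2 to compound 3 (0.37 log units; beyond the scatter) is modest. Of the two numbers shown, compound 3 holds the higher one, with compound 2 nearest to it.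

Compound 4 `C=CCc1nnn(Cc2ccc(C(F)(F)F)cc2)c1C(=O)N[C@@H](C)c1ccc(C(=O)O)cc1` differs from compound 3 by allyl in place of cyclohexyl on an aromatic carbon. The step bearing most directly on this change is a 2.3-fold higher number from compound 2 to compound 3 (0.37 log units; beyond the scatter), where cyclohexyl replaced propyl and brought a modest rise; putting allyl, counted at 3 heavy atoms like propyl, in place of cyclohexyl would be expected to undo roughly that step. The steps of an at least 140-fold lower number from compound 1 to compound 2 (2.16 log units; beyond the scatter) and an at least 62-fold lower number from compound 1 to compound 3 (1.79 log units; beyond the scatter) show that the group on this aromatic carbon can shift the number greatly. In this assay compound 4 is therefore expected to give 80 nM, between 30 nM and 220 nM. The step of a 2.0-fold lower number from compound 3 to compound 4 (0.30 log units; within the scatter) is expected to be modest and downward.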

Compound 4, half-maximal inhibitory concentration: > 1000 nM
Compound 4: only a limit was reported; the forecaster's own chance of this, stated with the estimate: 2%; middle value at least 12-fold (1.09 log units) from the limit.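

In this assay compound 4 is reported only as > 1000 nM, which is a limit of the assay and not a number: the limit of > 1000 nM in this assay, at which 1 of the 4 values shown sits.

Set against the cyclohexyl group, allyl gives an at least 6.2-fold higher number from compound 3 to compound 4 (0.79 log units; beyond the scatter), and set against the propyl chain it gives an at least 14-fold higher number from compound 2 to compound 4 (1.16 log units; beyond the scatter), so the earlier large steps at this aromatic carbon are no longer the only sign of its sensitivity: a change confined to the end of the chain, with a double bond outside aromatic rings entering, is enough to produce a large shift. Among the compounds shown, propyl and cyclohexyl return measured numbers while ethyl and allyl return only limits, and the step between compound 1 and compound 4 cannot be read, as both ends of it are limits.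

Where the number for compound 4 actually lies, and whether the double bond or the shape of the allyl chain carries the loss, stays open. As far as these compounds go, how butyl, isopropyl or methoxymethyl on this aromatic carbon would compare with propyl and cyclohexyl in this assay also remains open.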